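The compounds below may be only part of what the source reports. "The series", "measured", "known", "first", "only" and "open" are said of these compounds alone.

Working notes on the series. The three measured compounds share one core and differ only in the group carried on one aromatic carbon of that core. In an assay on isolated protein for inhibition of acid ceramidase (Homo sapiens), read by LC-MS, with a stated time of 1 h (a lower number here means a stronger inhibitor, a higher number a weaker inhibitor), compound 1 `O=C(NCCCCc1ccccc1)n1cc(-c2ccc(F)cc2)oc1=O` gives 185 nM. Compound 2 `COc1ccc(-c2cn(C(=O)NCCCCc3ccccc3)c(=O)o2)cc1` gives 400 nM. Compound 3 `O=C(NCCCCc1ccccc1)n1cc(-c2cnccn2)oc1=O` gives 32 nM, the lowest of the three numbers, and its steps to both others lie beyond the scatter. The measured steps are a 2.2-fold higher number from compound 1 to compound 2 (0.33 log units; beyond the scatter), a 5.8-fold lower number from compound 1 to compound 3 (0.76 log units; beyond the scatter) and a 13-fold lower number from compound 2 to compound 3 (1.10 log units; beyond the scatter).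

Compound 4 `CN1CCC(c2cn(C(=O)NCCCCc3ccccc3)c(=O)o2)CC1` is not yet measured. The change from compound 3 is 1-methylpiperidin-4-yl in place of pyrazin-2-yl on an aromatic carbon. Among the measured compounds shown here, none of the measured steps bears on it directly: each of them exchanges one aromatic group for another, whereas here a non-aromatic ring enters. Those steps show that the group at this position shifts the number by modest to large amounts in either direction, so a step beyond the scatter is expected, most likely toward a higher number, with wide uncertainty. Compound 4 is expected to give 150 nM in this assay, within 30 nM to 800 nM. That estimate means an expected step of a 4.7-fold higher number from compound 3 to compound 4 (0.67 log units; beyond the scatter).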

Compound 4, half-maximal inhibitory concentration: 1400 nM
The estimate for compound 4 lay 9.3-fold (0.97 log units) below the measured number; measured number outside the range, above it.
By their numbers in this assay, from the lowest: compound 3; then compound 1; then compound 2; then compound 4.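

In this assay, compound 4 is the weakest of the four, and its 1-methylpiperidin-4-yl group is the only non-aromatic ring yet seen at this position: a 44-fold higher number from compound 3 to compound 4 (1.64 log units; beyond the scatter), a 3.5-fold higher number from compound 2 to compound 4 (0.54 log units; beyond the scatter) and a 7.6-fold higher number from compound 1 to compound 4 (0.88 log units; beyond the scatter). The earlier steps only exchanged one aromatic group for another, whereas these three all run in the same direction, with no compound shown going against it, so pyrazin-2-yl, 4-fluorophenyl and 4-methoxyphenyl all give lower numbers than this non-aromatic ring. No measured evidence on why the number rises is available.

The compounds shown do not separate the loss of the aromatic ring from the presence of the ring nitrogen and its methyl group. A cyclohexyl ring or an unsubstituted piperidin-4-yl group at this position would help to tell these apart.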